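Adding Bromine to the Phenyl Ring of the Sulfonamide

The source may hold more compounds than are shown below. What is called first, only, known or untested is meant among the compounds shown, and "the series" means these compounds.

Measured so far:
Compound 1, `CN(c1ccccc1)S(=O)(=O)C1CC2OC1C(c1ccc(NC(=O)CCCCCCC(=O)O)cc1)=C2c1ccc(O)cc1`: 63800 nM
Compound 2, `CCN(c1ccccc1)S(=O)(=O)C1CC2OC1C(c1ccc(NC(=O)CCCCCCC(=O)O)cc1)=C2c1ccc(O)cc1`: 19100 nM

Both compounds were tested in a functional assay on MCF7 cells (Homo sapiens) for antiproliferative activity, read by MTT assay, with a stated time of 72 h; a lower number here means a stronger inhibitor, a higher number a weaker inhibitor. For the measured compounds named here, compound 2 holds the lowest of the two numbers seen, and its only neighbour is compound 1, which sits higher by a 3.3-fold lower number from compound 1 to compound 2 (0.52 log units; beyond the scatter), a step that came from a change at the sulfonamide nitrogen.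

The next compound, compound 3, `CCN(c1ccccc1Br)S(=O)(=O)C1CC2OC1C(c1ccc(NC(=O)CCCCCCC(=O)O)cc1)=C2c1ccc(O)cc1`, keeps everything in compound 2 and differs only here: bromo in place of hydrogen on an aromatic carbon. Going by the values given here, no measured pair shows what a bromo on that ring does. Among the compounds with values here, the one step available, the one from compound 1 to compound 2, touches the same nitrogen from a different side and speaks to it only loosely. With so little to lean on, the expectation is a step of a 1.3-fold lower number from compound 2 to compound 3 (0.10 log units; within the scatter), close to the scatter of the assay and uncertain in direction. Compound 3 is therefore estimated at 15000 nM, within a range from 5000 nM to 50000 nM.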

Compound 3, half-maximal inhibitory concentration: > 100000 nM
Compound 3: a limit, no number; the forecaster's own chance of this, stated with the estimate: 10%; middle value at least 6.6-fold (0.82 log units) away from the limit.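

In this assay compound 3 gives > 100000 nM, which is a limit of the assay and not a number, and it is the only such result among these compounds: the limit of > 100000 nM in this assay, at which 1 of the 3 values shown sits.

Even so, the limit is informative, since a single bromo on an aromatic carbon, ortho to a large group, produces an at least 5.2-fold higher number from compound 2 to compound 3 (0.71 log units; beyond the scatter). This position on the phenyl ring therefore responds clearly to substitution, and the change runs in the opposite direction to the earlier change at the sulfonamide nitrogen, a 3.3-fold lower number from compound 1 to compound 2 (0.52 log units; beyond the scatter). The comparison with the methyl compound gives a smaller floor, an at least 1.5-fold higher number from compound 1 to compound 3 (0.19 log units; that floor lies within the scatter), so compound 3 keeps none of the gain seen with the ethyl group, but how far it lies beyond that floor cannot be read.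

The compounds shown leave open whether this loss belongs to bromo in particular or to any group on this carbon: a fluoro, a methyl or a methoxy in the same place would separate the two. They also leave open whether a hydroxyl or an amine on this ring would be treated any differently in this cell assay.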